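The compounds below may be only part of what the source reports. "The series", "measured", "known", "first", "only" and "open" are said of these compounds alone.

Measured so far in a functional assay on A2780 cells (Homo sapiens) for inhibition, read by sulforhodamine B assay, with a stated time of 72 h; on this read-out higher numbers stand for weaker inhibition and lower numbers for stronger inhibition:
Compound 1 `O=C(Nc1ccc(S(=O)(=O)N2CCCCC2)cc1)c1cc2cnccc2[nH]1`, a limit of the assay: > 10000 nM
Compound 2 `O=C(NCc1ccc(S(=O)(=O)N2CCCCC2)cc1)c1cc2cnccc2s1`: 1600 nM
Compound 3 `O=C(NCc1ccc(S(=O)(=O)N2CCCCC2)cc1)c1ccn2cncc2c1`, a limit of the assay: > 10000 nM

Compound 3 therefore sits at the limit where two of the three values stand (the limit of > 10000 nM in this assay, at which 2 of the 3 values shown sit), and only compound 2 gives a number. Compound 4 `O=C(NCc1ccc(S(=O)(=O)N2CCCCC2)cc1)c1cc2ccncc2[nH]1` is made from compound 3 by a group of 9 heavy atoms (7 carbon, 2 nitrogen; one five-membered aromatic ring with 1 hetero atom, one six-membered aromatic ring with 1 hetero atom) in place of a group of 9 heavy atoms (7 carbon, 2 nitrogen; one five-membered aromatic ring with 2 hetero atoms, one six-membered aromatic ring with 1 hetero atom), on a carbonyl carbon. Within the data shown here, the single measured step that bears on this part of the molecule, an at least 6.2-fold higher number from compound 2 to compound 3 (0.79 log units; beyond the scatter), shows that exchanging the ring pair on the carbonyl carbon can move this assay by a modest amount. Since compound 3 is only a limit, the step to compound 4 is expected to fall in the direction of stronger inhibition, an at least 2.8-fold lower number from compound 3 to compound 4 (0.45 log units; beyond the scatter), and compound 4 is estimated at 3500 nM (range 900 nM to 14000 nM).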

Compound 4, half-maximal inhibitory concentration: 1700 nM
Estimate against measurement, compound 4: 2.1-fold (0.31 log units) above; the range from low to high includes it.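

In this assay, exchanging the ring pair on the carbonyl carbon can also recover measurable inhibition, with an at least 5.8-fold lower number from compound 3 to compound 4 (0.76 log units; beyond the scatter). A ring pair without sulfur can stand level with the sulfur-containing one of compound 2, with a 1.1-fold higher number from compound 2 to compound 4 (0.03 log units; within the scatter). Compound 3 remains a limit of the assay, so the first step gives only a bound: the limit of > 10000 nM in this assay, at which 2 of the 4 values shown sit.

The compounds shown leave open whether the hydrogen-bond donor of the entering group matters. They also leave open whether a methyl group or an amine on this ring pair would keep inhibition at this level.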